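A Methylphenyl Urea Measured Against Its Iodo Counterpart

The source may hold more compounds than are shown below. What is called first, only, known or untested is meant among the compounds shown, and "the series" means these compounds.

Compound 3 `O=C(Nc1ccc(I)cc1)N[C@H]1CC[C@H](Oc2ccc(F)cc2)CC1` is the only one of the three measured ureas that returns a number in a functional assay on CRL2813 cells (Homo sapiens) for cytotoxicity, read by sulforhodamine B assay, with a stated time of 5 days (a higher number here means a weaker inhibitor, a lower number a stronger inhibitor), where compound 3 gives 10200 nM. Compound 1 `O=C(Nc1ccc(Br)cc1)N[C@H]1CC[C@H](Oc2ccc(F)cc2)CC1` sits at a limit of this assay, giving > 20000 nM. Compound 2 `Cc1ccc(NC(=O)N[C@H]2CC[C@H](Oc3ccc(F)cc3)CC2)cc1` likewise sits at a limit, giving > 20000 nM. The steps of an at least 1.9-fold lower number from compound 1 to compound 3 (0.29 log units; that floor lies within the scatter) and an at least 1.9-fold lower number from compound 2 to compound 3 (0.29 log units; that floor lies within the scatter) are therefore both floors resting on (the limit of > 20000 nM in this assay, at which 2 of the 3 values shown sit). Compound 4 `Cc1ccccc1NC(=O)N[C@H]1CC[C@H](Oc2ccc(F)cc2)CC1` differs from compound 3 by 2-methylphenyl in place of 4-iodophenyl on an amide-type nitrogen. The step from compound 2 to compound 3 also exchanges iodo for methyl and is the closest guide. The number for compound 4 is thus expected to rise by an estimated 2.5-fold higher number from compound 3 to compound 4 (0.39 log units; beyond the scatter), most likely back to the limit. Compound 4 is estimated at 25000 nM, within 8000 nM to 80000 nM.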

Compound 4, half-maximal inhibitory concentration: > 20000 nM
Compound 4: no number, only a limit; the forecaster's own chance of this, stated with the estimate: 70%; the middle value is on the limit's open side.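

In this assay, 2-methylphenyl in place of 4-iodophenyl on the amide-type nitrogen gives an at least 1.9-fold higher number from compound 3 to compound 4 (0.29 log units; that floor lies within the scatter). Going by these compounds alone, compound 3 thus remains the only compound with a number, and this floor rests on the following: the limit of > 20000 nM in this assay, at which 3 of the 4 values shown sit. The steps from compound 1 and from compound 2 to compound 4 join two limits and cannot be read, so 2-methylphenyl and 4-methylphenyl cannot be told apart here.

From the compounds shown here alone, what stays open is how far any of these limited compounds actually lies from compound 3. Also open, going by these compounds, is how a phenyl ring carrying an amine or a carboxylic acid would read in this assay.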